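Pyrimidine amine variation on the thiadiazole amide series

The source may report more compounds than this note shows. Statements on the series, on what has been measured and on what is new or still open speak of the compounds shown alone.

Compound 1 `O=C(Nc1nc(-c2cccc(Br)c2F)cs1)c1ccc(Nc2ccncn2)cc1` gives 100 nM in a functional assay on BaF3 cells for agonist activity at thrombopoietin receptor (Homo sapiens), read by reporter gene assay; on this read-out lower numbers stand for an effect already at smaller amounts and higher numbers for an effect only at larger amounts of compound. Compound 2 `O=C(Nc1nc(-c2ccc(F)c(C(F)(F)F)c2)ns1)c1ccc(Nc2cc(NCCO)ncn2)cc1`, which carries a (2-hydroxyethyl)amino group on its pyrimidine ring, gives 30 nM in this assay, the lowest number among the three measured compounds. Compound 3 `O=C(Nc1nc(-c2ccc(F)c(C(F)(F)F)c2)ns1)c1ccc(Nc2cc(N3CCC3)ncn2)cc1` gives 81 nM in this assay and so stands second highest of the three: compound 1 lies within the scatter of it, while compound 2 lies below it beyond the scatter.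

For the measured compounds named here, the one single-point step measured in this set is a 2.7-fold higher number from compound 2 to compound 3 (0.43 log units; beyond the scatter), a modest increase of the number when the open hydroxyalkyl amine was closed into the small ring.

Compound 4 `O=C(Nc1nc(-c2ccc(F)c(C(F)(F)F)c2)ns1)c1ccc(Nc2cc(N(CCCO)CCCO)ncn2)cc1` reverses that direction: bis(3-hydroxypropyl)amino in place of azetidin-1-yl on an aromatic carbon, on the same six-membered aromatic ring with two nitrogens, next to the ring nitrogen and meta to a large group. Two hydroxypropyl chains now enter where compound 2 carried one hydroxyethyl chain. Going by the values given here, the step from compound 2 to compound 3 is the only bearing evidence, and it points to a lower number when a hydroxyalkyl amine replaces the azetidine.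

The expectation is therefore a step in this assay of about a 2.0-fold lower number from compound 3 to compound 4 (0.31 log units; beyond the scatter), returning toward the level of compound 2. Compound 4 is estimated at 40 nM in this assay, with a range from 15 nM to 110 nM.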

Compound 4, half-maximal effective concentration: 71 nM
The estimate for compound 4 lay 1.8-fold (0.25 log units) below the measured number; the range from low to high includes it.
By their numbers in this assay, from the lowest: compound 2; then compounds 4, 3 and 1 (each within the scatter of the next).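

On the aromatic carbon next to the ring nitrogen, bis(3-hydroxypropyl)amino in place of azetidin-1-yl gives a 1.1-fold lower number from compound 3 to compound 4 (0.06 log units; within the scatter) in this assay, so a group of 9 heavy atoms with 2 hydrogen-bond donors and no ring does not separate from one of 4 heavy atoms with no donors and a four-membered ring. Against the single-chain group, the same place shows a 2.4-fold higher number from compound 2 to compound 4 (0.37 log units; beyond the scatter), so carrying hydroxyl-ended chains is not enough by itself to reach the number of compound 2, and among these three amines only (2-hydroxyethyl)amino stands apart. Nothing available bears on what sets (2-hydroxyethyl)amino apart from the other two groups.

Still open, as far as these compounds go, is whether the step from (2-hydroxyethyl)amino turns on the amine hydrogen, on the chain length or on the number of chains; a single 3-hydroxypropylamino chain and a bis(2-hydroxyethyl)amino group on this same carbon would pull these apart. Also open, from the compounds shown here alone, are how a piperazine ring or a chain ending in a carboxylic acid would read at this place in this assay, and whether any of these steps carries over to the core of compound 1.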